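Swapping fluoro for methyl on compound 1

The compounds below may be only part of what the source reports. "The series", "measured", "known", "first", "only" and "open" are said of these compounds alone.

Compound 1 `C[C@@H](Oc1cc2oc(=O)n(CCC(=O)O)c2cc1Cl)c1ccc(F)cn1` gives 31 nm/s in a physicochemical assay for permeability, using PAMPA (a higher number here means that the compound crosses the layer faster, a lower number that the compound crosses the layer more slowly), the highest of the three numbers measured. Compound 2 `O=C(O)CCn1c(=O)oc2cc(OCC3CC3)c(Cl)cc21` gives 19 nm/s, which lies within the scatter of compound 1, while compound 3 `O=C(O)CCn1c(=O)oc2cc(OCC3CCC3)c(Cl)cc21` gives 12 nm/s, beyond it. Among the measured compounds shown here, the one measured step, a 1.6-fold lower number from compound 2 to compound 3 (0.20 log units; within the scatter), concerns a different part of the shared core and stays within the scatter. Compound 4 `Cc1ccc([C@@H](C)Oc2cc3oc(=O)n(CCC(=O)O)c3cc2Cl)nc1` differs from compound 1 by methyl in place of fluoro on an aromatic carbon, which read one bond further out is a change from 5-fluoropyridin-2-yl to 5-methylpyridin-2-yl. For the measured compounds named here, no measured step touches this place, so no change beyond the scatter is expected: no change at the digits printed from compound 1 to compound 4 (within the scatter). Compound 4 is therefore estimated at 31 nm/s, with a range from 16 nm/s to 60 nm/s.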

Compound 4, apparent permeability: 22 nm/s
For compound 4 the middle estimate is 1.4-fold (0.15 log units) above the measured one; the range from low to high includes it.
By their numbers in this assay, from the lowest: compounds 3, 2, 4 and 1 (each within the scatter of the next, the first and the last beyond it).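

In this assay, among the compounds shown here, the change reads a 1.4-fold lower number from compound 1 to compound 4 (0.15 log units; within the scatter) and is the first measured step at this position on the aromatic ring. On the shared core of these two compounds, 5-fluoropyridin-2-yl and 5-methylpyridin-2-yl therefore cannot be told apart in this read-out. Nothing measured here offers an explanation for this result.

Going by these compounds, whether an amine or a methoxy group on this aromatic carbon would also stay within the scatter of compound 1 remains open. So does whether a longer chain in place of methyl would do the same.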